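Swapping the group on the saturated ring carbon

The compounds below may be only part of what the source reports. "The series", "measured", "known", "first", "only" and "open" are said of these compounds alone.

Measured compounds:
- compound 1, `COc1cc(N2C(N)=C(C#N)C(c3ccc([N+](=O)[O-])cc3)C3=C2CC(C)(C)CC3=O)cc(OC)c1OC`: 10%
- compound 2, `COc1cc(N2C(N)=C(C#N)C(c3ccc(Cl)cc3Cl)C3=C2CC(C)(C)CC3=O)cc(OC)c1OC`: 20%

In a functional assay on Ehrlich cells (Mus musculus) for cytotoxicity, tested at 10 ug/mL (on this read-out higher numbers stand for a stronger effect at the one concentration tested and lower numbers for a weaker effect), compound 2 stands highest of the two numbers available, with compound 1 nearest; the step of a number 10 percentage points higher from compound 1 to compound 2 (within the scatter) is within the scatter, so the two cannot be ordered on this read-out. Compound 3, `COc1cc(N2C(N)=C(C#N)C(c3ccc(C)o3)C3=C2CC(C)(C)CC3=O)cc(OC)c1OC`, has not been measured. It differs from compound 2 in one place: 5-methylfuran-2-yl in place of 2,4-dichlorophenyl on a saturated ring carbon. Among the measured compounds shown here, the only measured step that bears on this change is the one from compound 1 to compound 2, which also exchanged the group on that same saturated ring carbon and gave a number 10 percentage points higher from compound 1 to compound 2 (within the scatter), a difference that stays within the scatter. The record thus offers no sign that this position moves the read-out in this assay by more than the usual spread. For compound 3 the expected step is therefore a number 5 percentage points lower from compound 2 to compound 3 (within the scatter), a change not expected to exceed the scatter. The estimate for compound 3 in this assay is 15%, with a range from 2% to 35%.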

Compound 3, a percentage reported as activity, at one concentration (the size of the read-out at that concentration, not a potency): 21%
Estimate against measurement, compound 3: 6 percentage points below; measured number inside the range.
By their numbers in this assay, from the lowest: compounds 1, 2 and 3 (each within the scatter of the next, the first and the last beyond it).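

In this assay, the 5-methylfuran-2-yl group, a five-membered aromatic ring with 1 hetero atom, takes the place of the six-membered 2,4-dichlorophenyl group on the saturated ring carbon without a difference that can be read (a number 1 percentage points higher from compound 2 to compound 3 (within the scatter)), so this position accepts a change of ring size and the entry of a hydrogen-bond acceptor with no step beyond the usual spread. Set against the 4-nitrophenyl group, the same 5-methylfuran-2-yl group gives the first step at this position that passes the scatter (a number 11 percentage points higher from compound 1 to compound 3 (beyond the scatter)), and this modest step is the first sign that the group on this carbon can shift the read-out at all, although compound 2 remains within the scatter of both other compounds. Nothing measured in this account explains either step.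

On these data alone, all three groups on this carbon are aromatic rings, so it remains open what an open-chain group such as n-butyl, a saturated ring such as cyclohexyl, or a phenyl ring carrying a carboxylic acid or a dimethylamino group would give. As far as these compounds go, it also remains open whether these small differences at the single concentration of this assay would carry over to differences in potency.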